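The compounds below may be only part of what the source reports. "The series", "measured", "known", "first", "only" and "open" are said of these compounds alone.

Of the compounds shown here, three with the same shared core have been measured in a functional assay, read by spectrophotometry, with a stated time of 6 min; on this read-out higher numbers stand for an effect only at larger amounts of compound and lower numbers for an effect already at smaller amounts. Compound 1 `COc1c(C)cc(O)cc1/C=C/C(C)(O)CC(=O)/C=C(/C)CCCC(C)C(=O)/C=C/C(C)(C)O` gives 22500 nM, compound 2 `COc1c(C)cc(O)cc1C/C=C(\C)CC(=O)/C=C(/C)CCCC(C)C(=O)/C=C/C(C)(C)O` gives 26300 nM, and compound 3 `COc1c(C)cc(O)cc1C/C=C(\C)CC(=O)/C=C(\C)CCCC(C)C(=O)/C=C/C(C)(C)O` gives 24500 nM. Compound 3 therefore stands with the other two, all three numbers lying within the scatter of one another.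

Compound 4 `COc1c(C)cc(O)cc1C/C=C(\C)CC(=O)/C=C(\C)CCCC(C)=O` departs from compound 3 in one place: acetyl in place of 1-((3-hydroxy-3-methylbut-1-en-1-yl)carbonyl)ethyl on a saturated chain carbon, three bonds along the chain from a double-bonded chain carbon. Acetyl takes the place of 1-((3-hydroxy-3-methylbut-1-en-1-yl)carbonyl)ethyl on a saturated chain carbon, three bonds along the chain from a double-bonded chain carbon.

Within the data shown here, only one measured step links two compounds that differ in one place. This is a 1.1-fold lower number from compound 2 to compound 3 (0.03 log units; within the scatter), where a double bond is drawn Z in one compound and E in the other. That step is small, but it leaves the departing group untouched, so it says little about removing that group. Among the measured compounds shown here, the data offer no measured precedent for this cut and no direction for it in this assay, so no shift beyond the scatter is expected, though with low confidence. The expected change is a 1.1-fold higher number from compound 3 to compound 4 (0.06 log units; within the scatter), and this estimate carries a wide margin. For compound 4 the estimated value is 28000 nM, with an expected range of 10000 nM to 80000 nM.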

Compound 4, half-maximal effective concentration: 33300 nM
Compound 4: the middle estimate sits 1.2-fold (0.08 log units) below what was measured; the range from low to high includes it.
By their numbers in this assay, from the lowest: compounds 1, 3, 2 and 4 (each within the scatter of the next).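

In this assay, the step from the larger group to acetyl on a saturated chain carbon, three bonds along the chain from a double-bonded chain carbon, gives a 1.4-fold higher number from compound 3 to compound 4 (0.13 log units; within the scatter). Unlike the earlier comparison, which left this part of the molecule intact, this step removes 1-((3-hydroxy-3-methylbut-1-en-1-yl)carbonyl)ethyl with its 10 heavy atoms, its 2 double bonds and its hydrogen-bond donor, yet the change stays within the scatter, so in this read-out that group can give way to the 3 heavy atoms of acetyl without a shift that can be told from repeat variation. The information at hand offers nothing that would account for this result.

With only acetyl and the larger group shown at this place, it remains open whether any other group there would move the number beyond the scatter, for instance a carboxylic acid, an amine or a longer chain ending in a ketone. On these data alone, it also remains open whether the double-bond drawing that separates compound 2 from compound 3 would matter in a compound carrying acetyl.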